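Replacing the formyl group of compound 2

The source may report more compounds than this note shows. Statements on the series, on what has been measured and on what is new or still open speak of the compounds shown alone.

Measured in an ADME assay on HEK293 cells (Homo sapiens) for cytotoxicity, read by CCK-8 assay, with a stated time of 48 h; on this read-out lower numbers stand for stronger inhibition and higher numbers for weaker inhibition:
Compound 1 `COc1ccc(/C=C\c2cc(OC)c(OC)c(OC)c2)cc1OCc1ccc(CNC(C)(C)C(=O)O)cc1`: > 50000 nM (a limit)
Compound 2 `COc1ccc(/C=C\c2cc(OC)c(OC)c(OC)c2)cc1OCc1ccc(C=O)cc1`: 46000 nM

Among the compounds with values here, compound 2 gives 46000 nM, the only true number so far. Compound 1 reads > 50000 nM, which is a limit of the assay and not a number.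

Compound 3 `COc1ccc(/C=C\c2cc(OC)c(OC)c(OC)c2)cc1OCc1ccc(CN2C[C@H](O)C[C@@H]2C(=O)O)cc1` has not yet been measured. It carries (2-carboxy-4-hydroxypyrrolidin-1-yl)methyl in place of formyl on an aromatic carbon.

Within the data shown here, only one measured step bears on this change, an at least 1.0-fold lower number from compound 1 to compound 2 (0.03 log units; that floor lies within the scatter). It swaps formyl with ((1-carboxy-1-methylethyl)amino)methyl, the closest group on hand to the entering one. On these data alone, since that step gives only a floor, its true size remains open. No step beyond the scatter is therefore expected in this assay, and the reading may again be a limit. The expected step is a 1.2-fold higher number from compound 2 to compound 3 (0.08 log units; within the scatter). For compound 3 the estimated value is 55000 nM, with an expected range of 22000 nM to 130000 nM.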

Compound 3, half-maximal inhibitory concentration: > 50000 nM
Compound 3: a limit, no number; the forecaster's own chance of this, stated with the estimate: 65%; the middle value does not contradict the limit.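

In this assay compound 3 gives > 50000 nM as a limit of the assay and not a number. Placing (2-carboxy-4-hydroxypyrrolidin-1-yl)methyl in place of formyl, para to a large group, gives an at least 1.0-fold higher number from compound 2 to compound 3 (0.03 log units; that floor lies within the scatter) and so adds no step beyond the scatter. A group with a five-membered non-aromatic ring and 2 defined stereocentres thus ends at the same limit as the open-chain group of compound 1: the limit of > 50000 nM in this assay, at which 2 of the 3 values shown sit.

The step from compound 1 to compound 3 cannot be read, as both values are limits. Still open, on these data alone, are how far either compound lies past the limit and whether a group without the carboxylic acid, such as a plain aminomethyl, would read differently from formyl at this position.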